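Taking the chloro group off compound 2

The source may report more compounds than this note shows. Statements on the series, on what has been measured and on what is new or still open speak of the compounds shown alone.

In an ADME assay on BHK-21 cells (Mesocricetus auratus) for cytotoxicity, read by MTT assay, with a stated time of 72 h (on this read-out lower numbers stand for higher toxicity in this test and higher numbers for lower toxicity in this test), compound 1 `FC(F)(F)c1ccc(-c2nn(-c3ccccc3)cc2CNc2ccc(Cl)cc2)cc1` gives 31000 nM and compound 2 `Clc1ccc(NCc2cn(-c3ccccc3)nc2-c2ccc(Cl)cc2)cc1` gives 73000 nM as the higher of the two numbers. Within the data shown here, the single measured step is a 2.4-fold higher number from compound 1 to compound 2 (0.37 log units; beyond the scatter) with chloro in place of trifluoromethyl on an aromatic carbon, and it counts as modest. Compound 3 `Clc1ccc(NCc2cn(-c3ccccc3)nc2-c2ccccc2)cc1` alters that same carbon again: hydrogen in place of chloro on an aromatic carbon that is, hydrogen in place of chloro on an aromatic carbon, para to a large group, with 4-chlorophenyl going to phenyl.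

Among the measured compounds shown here, no compound with hydrogen at this carbon has a measured value yet, and one step sets no trend. For the measured compounds named here, compound 2 at 73000 nM is the starting point, and the step of a 2.4-fold higher number from compound 1 to compound 2 (0.37 log units; beyond the scatter) is the only guide to size. A modest step is therefore expected, tentatively toward a higher number in this assay with a lower number not ruled out. The expected change is a 1.2-fold higher number from compound 2 to compound 3 (0.07 log units; within the scatter) as a working estimate. Compound 3 is estimated at 85000 nM with an expected range from 35000 nM to 200000 nM for this measurement.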

Compound 3, half-maximal cytotoxic concentration: > 100000 nM
Compound 3 was reported as a limit; the forecaster's own chance of this, stated with the estimate: 25%; middle value at least 1.1-fold (0.07 log units) away from the limit.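

In this assay compound 3 gives > 100000 nM, which is a limit of the assay and not a number, and it is the only reading of this kind among the compounds shown: the limit of > 100000 nM in this assay, at which 1 of the 3 values shown sits.

Read against chloro, hydrogen at this aromatic carbon gives an at least 1.3-fold higher number from compound 2 to compound 3 (0.13 log units; that floor lies within the scatter), so this floor alone does not separate the hydrogen compound from the chloro compound, and the direction of the chloro-to-hydrogen change remains unproved even though the limit sits on the higher side. Read against trifluoromethyl, the same carbon gives an at least 3.2-fold higher number from compound 1 to compound 3 (0.50 log units; beyond the scatter), which adds a second comparison beyond the scatter and shows that, among these three compounds, trifluoromethyl carries the lowest number, a point the earlier chloro step alone could not extend to hydrogen.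

From the compounds shown here alone, how far compound 3 lies past its limit stays open, and with it the true size of both new steps. Among these compounds, also open is how an amine, a methoxy group or a carboxylic acid on this same carbon would read in this assay, since the series so far covers only trifluoromethyl, chloro and hydrogen here.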